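The source may hold more compounds than are shown below. What is called first, only, known or untested is meant among the compounds shown, and "the series" means these compounds.

Measured so far:
compound 1 `CC(=O)NC1CCN(c2nc3c(c(Nc4ccc(C(F)(F)F)cc4)n2)CCN(c2ncccc2C(F)(F)F)CC3)C1`; in a functional assay on HEK293 cells for antagonist activity at transient receptor potential cation channel subfamily V member 1 (Homo sapiens), read by FLIPR and calcium flux (a lower number here means a stronger inhibitor, a higher number a weaker inhibitor), compound 1 gives 150 nM
compound 2 `CCC(CC)N1CCN(c2nc3c(c(Nc4ccc(C(F)(F)F)cc4)n2)CCN(c2ncccc2C(F)(F)F)CC3)CC1`; compound 2 gives 41 nM
compound 3 `CN1CCCCC1CNc1nc2c(c(Nc3ccc(C(F)(F)F)cc3)n1)CCN(c1ncccc1C(F)(F)F)CC2`; compound 3 gives 1760 nM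

Compound 3 stands highest of the three numbers: a 12-fold higher number from compound 1 to compound 3 (1.07 log units; beyond the scatter) and a 43-fold higher number from compound 2 to compound 3 (1.63 log units; beyond the scatter). Compound 4 `NC1CCN(c2nc3c(c(Nc4ccc(C(F)(F)F)cc4)n2)CCN(c2ncccc2C(F)(F)F)CC3)C1` is not yet measured. The change from compound 3 is 3-aminopyrrolidin-1-yl in place of ((1-methylpiperidin-2-yl)methyl)amino on an aromatic carbon. The 3-aminopyrrolidin-1-yl of compound 4 is nearest in kind to the 3-acetamidopyrrolidin-1-yl of compound 1, so the step that bears on this change is a 12-fold higher number from compound 1 to compound 3 (1.07 log units; beyond the scatter), a large one; the step of a 3.7-fold lower number from compound 1 to compound 2 (0.56 log units; beyond the scatter) was modest and concerns another group. Undoing the large step to compound 3 points to a large lower number. Compound 4 is therefore expected to give 200 nM, range 60 nM to 700 nM, an expected step of an 8.8-fold lower number from compound 3 to compound 4 (0.94 log units; beyond the scatter).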

Compound 4, half-maximal inhibitory concentration: 3700 nM
Estimate against measurement, compound 4: 19-fold (1.27 log units) below, outside the stated range (above it).
By their numbers in this assay, from the lowest: compound 2; then compound 1; then compound 3; then compound 4.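

Taking the acetyl off the amine nitrogen gives a 25-fold higher number from compound 1 to compound 4 (1.39 log units; beyond the scatter), so at this position the five-membered ring alone does not hold the number down; the acetyl matters. The free 3-aminopyrrolidin-1-yl also falls behind the ((1-methylpiperidin-2-yl)methyl)amino group, with a 2.1-fold higher number from compound 3 to compound 4 (0.32 log units; beyond the scatter), and further behind the 4-(pentan-3-yl)piperazin-1-yl group, with a 90-fold higher number from compound 2 to compound 4 (1.96 log units; beyond the scatter). No measurement at hand explains these steps. Going by these compounds, whether a propionyl or a methanesulfonyl group on that amine nitrogen would match the acetyl stays open.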